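The source may hold more compounds than are shown below. What is called first, only, known or untested is meant among the compounds shown, and "the series" means these compounds.

Working notes on the series. In a functional assay on HCT-116 cells (Homo sapiens) for antiproliferative activity, read by MTT assay, with a stated time of 72 h (on this read-out lower numbers stand for stronger inhibition and higher numbers for weaker inhibition), compound 1 `O=C(CCc1cccc2c1B(O)OC2)NC1CCCCC1` gives > 100000 nM. That reading is a limit of the assay, not a number. Among the compounds with values here, compound 2 `O=C(CCc1cccc2c1B(O)OC2)Nc1cccc(I)c1` gives 2300 nM, the only actual number so far. Within the data shown here, the one measured step, an at least 43-fold lower number from compound 1 to compound 2 (1.63 log units; beyond the scatter), is large and puts 3-iodophenyl in place of cyclohexyl on an amide-type nitrogen.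

Compound 3 `O=C(CCc1cccc2c1B(O)OC2)Nc1cccc(-c2cccc(F)c2)c1` keeps that nitrogen substituent's inner aromatic ring and changes its outer group: 3-fluorophenyl in place of iodo on an aromatic carbon, meta to a large group. The measured step of an at least 43-fold lower number from compound 1 to compound 2 (1.63 log units; beyond the scatter) bears only indirectly, since it swapped the whole group on the nitrogen, and it gives no measure for this smaller change. The expected step, a 1.5-fold lower number from compound 2 to compound 3 (0.19 log units; within the scatter), is therefore modest, leaning lower and probably not beyond the scatter. For compound 3 the estimated value is 1500 nM, with an expected range of 300 nM to 8000 nM.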

Compound 3, half-maximal inhibitory concentration: 460 nM
Compound 3: middle estimate off by 3.3-fold (0.51 log units), on the high side; measured number inside the range.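

In this assay the number moves again with a change confined to the outer group, a 5.0-fold lower number from compound 2 to compound 3 (0.70 log units; beyond the scatter), so the group on this aromatic carbon counts, not only the aromatic ring that carries it. A 3-fluorophenyl is accepted here in place of the single iodo atom and gives the lower number, so this place is not restricted to a single-atom group in the two compounds compared. This is also the first step between two actual numbers, whereas compound 1 stands at a limit of the assay, so the earlier step has no exact size: the limit of > 100000 nM in this assay, at which 1 of the 3 values shown sits.

Open, as far as these compounds go, is how much of the lower number belongs to the added ring and how much to its fluorine, which a plain phenyl at this place would separate. Also open, from the compounds shown here alone, is how an amine or a carboxylic acid in place of that fluorine would read.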